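A few compounds are considered here, and "the series" means these few. Any claim that something is new, unique, unknown or untested is made for them only; others in the source may bear on it.

Measured compounds:
Compound 1 `O=C(Nc1cccc(-n2cc(-c3ccncc3)c(-c3cc(O)cc(Cl)c3)n2)c1)Nc1ccc(Cl)c(C(F)(F)F)c1`: 106%
Compound 2 `O=C(Nc1cccc(-n2cc(-c3ccncc3)c(-c3cc(O)cc(Cl)c3)n2)c1)Nc1ccc(Cl)c(Cl)c1`: 96%

In a functional assay on HCC 2998 cells (Homo sapiens) for inhibition, read by sulforhodamine B assay, with a stated time of 48 h, tested at 1 uM (a higher number here means a weaker effect of the compound at the concentration tested, a lower number a stronger effect), compound 1 gives 106%, the highest of the two numbers shown. Within the data shown here, compound 2 gives 96%, and the only measured step, a number 10 percentage points lower from compound 1 to compound 2 (within the scatter), stays within the scatter. Compound 3 `COc1cc(Cl)cc(-c2nn(-c3cccc(NC(=O)Nc4ccc(Cl)c(C(F)(F)F)c4)c3)cc2-c2ccncc2)c1` differs from compound 1 by methyl in place of hydrogen on an oxygen on an aromatic ring. Among the measured compounds shown here, no measured step touches the hydroxy group, so nothing bears directly on this change, and the one step available is itself small. Compound 3 is therefore expected to sit close to compound 1, with a number 6 percentage points lower from compound 1 to compound 3 (within the scatter) expected to stay within the scatter. Compound 3 is estimated to give 100%, between 85% and 115%.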

Compound 3, a percentage reported as activity, at one concentration (the size of the read-out at that concentration, not a potency): 97%
For compound 3 the middle estimate is 3 percentage points above the measured one; low and high end bracket the measured number.
By their numbers in this assay, from the lowest: compounds 2, 3 and 1 (each within the scatter of the next).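

In this assay, the change from hydroxy to methoxy gives a number 9 percentage points lower from compound 1 to compound 3 (within the scatter). Among these compounds, this is the first reading at this oxygen, and putting methyl in place of the hydrogen there leaves no change that can be told from the scatter. Nothing available explains this result.

From the compounds shown here alone, whether a longer chain on that oxygen, or an amine or a carboxylic acid in place of the hydroxy, would shift the number remains open. So does whether methoxy would behave the same alongside chloro in place of trifluoromethyl.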